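The compounds below may be only part of what the source reports. "The series", "measured", "known", "first", "only" and "open" are said of these compounds alone.

Measured so far:
compound 1 `CN(C)Cc1cc(C(=O)/C=C/c2ccccc2)cc(CN(C)C)c1O`: 21900 nM
compound 2 `CN(C)Cc1cc(C(=O)/C=C/c2ccccc2Cl)cc(CN(C)C)c1O`: 9550 nM
compound 3 `CN(C)Cc1cc(C(=O)/C=C/c2cccc(Cl)c2)cc(CN(C)C)c1O`: 4680 nM

In a functional assay on cells (Tumor Cell line, Homo sapiens) for cytotoxicity (a higher number here means a weaker inhibitor, a lower number a stronger inhibitor), compound 1 stands highest of the three numbers, so it is the weakest of this set. Both known steps move downward: a 2.3-fold lower number from compound 1 to compound 2 (0.36 log units; beyond the scatter) and a 4.7-fold lower number from compound 1 to compound 3 (0.67 log units; beyond the scatter), each a chloro in place of hydrogen on an aromatic carbon, and between the two chloro positions a 2.0-fold lower number from compound 2 to compound 3 (0.31 log units; beyond the scatter). Compound 4 `CN(C)Cc1cc(C(=O)/C=C/c2c(F)cccc2Cl)cc(CN(C)C)c1O` differs from compound 1 by 2-chloro-6-fluorophenyl in place of phenyl on a double-bonded chain carbon bound to a double-bonded chain carbon. For the measured compounds named here, the chloro it carries matches the one of compound 2, and a fluorine is added besides; no measured step covers that fluorine. A modest drop beyond the scatter is therefore expected, near the size seen for compound 2. Compound 4 is estimated at 8000 nM (range 3000 nM to 20000 nM), a step of a 2.7-fold lower number from compound 1 to compound 4 (0.44 log units; beyond the scatter).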

Compound 4, half-maximal inhibitory concentration: 9120 nM
Estimate against measurement, compound 4: 1.1-fold (0.06 log units) below; the measured number falls inside the stated range.
By their numbers in this assay, from the lowest: compounds 3, 4 and 2 (each within the scatter of the next, the first and the last beyond it); then compound 1.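

In this assay, adding a fluorine leaves the number within the scatter (a 1.0-fold lower number from compound 2 to compound 4 (0.02 log units; within the scatter)), so this added fluorine shows no separate effect here. The 2-chloro-6-fluorophenyl group keeps the modest gain over phenyl (a 2.4-fold lower number from compound 1 to compound 4 (0.38 log units; beyond the scatter)), and it cannot be separated from 3-chlorophenyl (a 1.9-fold higher number from compound 3 to compound 4 (0.29 log units; within the scatter)). No measurement available here explains these steps.

Still open, as far as these compounds go, is how a methoxy or trifluoromethyl group in place of the chloro would compare.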